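Working notes: benzyl in place of phenyl on compound 2

The compounds below may be only part of what the source reports. "The series", "measured", "known", "first", "only" and "open" are said of these compounds alone.

Measured compounds:
- Compound 1 `[O-]/[N+](=C\c1cn(-c2ccccc2)nn1)c1ccccc1`: in a functional assay on COLO 205 cells (Homo sapiens) for inhibition, read by MTT assay, with a stated time of 24 h (on this read-out lower numbers stand for stronger inhibition and higher numbers for weaker inhibition), compound 1 gives > 100000 nM, which is a limit of the assay and not a number.
- Compound 2 `[O-]/[N+](=C\c1cn(CCC(F)(F)C(F)(F)C(F)(F)C(F)(F)C(F)(F)C(F)(F)C(F)(F)C(F)(F)F)nn1)c1ccccc1`: in this assay compound 2 gives > 100000 nM, again a limit of the assay.
- Compound 3 `[O-]/[N+](=C\c1cn(-c2ccc(F)cc2)nn1)Cc1ccccc1`: in this assay compound 3 gives > 100000 nM, also a limit of the assay.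

Compound 2 therefore stands nowhere in particular on the numbers shown: its value is only a limit, and the two other values shown are limits as well, so no ordering among compound 1, compound 2 and compound 3 can be read. All that is known is the limit of > 100000 nM in this assay, at which 3 of the 3 values shown sit.

The unmeasured compound 4 `[O-]/[N+](=C\c1cn(CCC(F)(F)C(F)(F)C(F)(F)C(F)(F)C(F)(F)C(F)(F)C(F)(F)C(F)(F)F)nn1)Cc1ccccc1` differs from compound 2 by benzyl in place of phenyl on a double-bonded nitrogen, in words: benzyl in place of phenyl on a double-bonded nitrogen. Within the data shown here, no step between measured compounds exists to size this change. Compound 3 carries the same benzyl group and sits at the limit, so no movement beyond the scatter is expected in this assay. The expected step from compound 2 to compound 4 is a step that the limit leaves unreadable from compound 2 to compound 4. For compound 4 the estimate is 150000 nM, with a range from 50000 nM to 500000 nM, most likely reported as a limit again.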

Compound 4, half-maximal inhibitory concentration: 9400 nM
Beside the measured number, compound 4's estimate is 16-fold (1.20 log units) above it, outside the stated range (below it).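

In this assay, among these compounds, benzyl in place of phenyl on a double-bonded nitrogen gives an at least 10-fold lower number from compound 2 to compound 4 (1.02 log units; beyond the scatter) and shows that this position can move the read-out, which the earlier compounds could not show. Compound 3 also carries benzyl at this place and gives > 100000 nM as a limit of the assay, so benzyl alone does not bring a number. Among the compounds shown, a number appears only where benzyl and the chain of compound 4 occur together, a single case against the rest: the limit of > 100000 nM in this assay, at which 3 of the 4 values shown sit.

On these data alone, whether a phenethyl group at this nitrogen would lower the number further remains open. Also open, as far as these compounds go, is whether a plain decyl chain could replace the fluorinated chain of compound 4 and keep a measurable value.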